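Hydroxybenzyl variant of compound 1: working notes

The source may report more compounds than this note shows. Statements on the series, on what has been measured and on what is new or still open speak of the compounds shown alone.

Compound 1 `COc1cccc(CNCc2c(C(=O)O)n(Cc3ccccc3)c3cc(C(C)C)ccc23)c1` is the reference point. Among the compounds with values here, in a functional assay on Bel-7402 cells (Homo sapiens) for antiproliferative activity, read by MTT assay, with a stated time of 72 h (a lower number here means a stronger inhibitor, a higher number a weaker inhibitor), compound 1 gives 5900 nM, the lowest of the two numbers read so far. Compound 2 `COc1ccc(Cn2c(C(=O)O)c(CNCc3cccc(OC)c3)c3ccccc32)cc1` gives 52900 nM in this assay. Compound 3 `COc1cccc(CNCc2c(C(=O)O)n(Cc3ccccc3)c3ccccc23)c1` reaches only a limit of the assay, > 50000 nM, with no number behind it (the limit of > 50000 nM in this assay, at which 1 of the 3 values shown sits). Within the data shown here, the step of an at least 8.4-fold higher number from compound 1 to compound 3 (0.92 log units; beyond the scatter) is the single readable step; the step that the limit leaves unreadable from compound 2 to compound 3 cannot be sized.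

Compound 4 `COc1cccc(CNCc2c(C(=O)O)n(Cc3ccc(O)cc3)c3cc(C(C)C)ccc23)c1` differs from compound 1 by hydroxy in place of hydrogen on an aromatic carbon; cut one bond further out this reads benzyl to 4-hydroxybenzyl. Among the measured compounds shown here, no measured step touches that ring: the readable step concerns the isopropyl, and the methoxy on the benzyl ring of compound 2 has no readable partner step. With nothing in the series pointing either way, no step beyond the scatter is expected in this assay.

Compound 4 is therefore estimated at 6000 nM, within 2000 nM to 20000 nM, which means an expected step of a 1.0-fold higher number from compound 1 to compound 4 (0.01 log units; within the scatter).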

Compound 4, half-maximal inhibitory concentration: 7080 nM
The estimate for compound 4 lay 1.2-fold (0.07 log units) below the measured number; measured number inside the range.
By their numbers in this assay, from the lowest: compounds 1 and 4 (each within the scatter of the next); then compound 2.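

In this assay, within the data shown here, the change from benzyl to 4-hydroxybenzyl gives a 1.2-fold higher number from compound 1 to compound 4 (0.08 log units; within the scatter), the first readable step on this ring. The earlier compounds shown here offered none here, since the methoxy on that ring in compound 2 has only a limit of the assay as its partner in compound 3. The new step shows that, on the core of compound 1, a hydroxy para to a large group keeps the number within the scatter, and no measurement shown here bears on the reason for this result.

From the compounds shown here alone, whether a nitrile or a fluorine in the same place would also stay within the scatter remains open. So does whether the hydroxy would give a similar step on a core without the isopropyl.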